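A few compounds are considered here, and "the series" means these few. Any claim that something is new, unique, unknown or untested is made for them only; others in the source may bear on it.

Measured compounds:
compound 1, `CNc1nnc(Cn2c(=O)oc3ccc(C)cc32)s1`: 96%
compound 2, `CCCn1c(Cn2c(=O)oc3ccc(C)cc32)n[nH]c1=S`: 160%

Both numbers come from a functional assay on the whole organism with Mus musculus as the target, read by paw edema, with a stated time of 360 min, at a dose of 50 mg/kg by the oral route; a lower number here means a stronger effect, a higher number a weaker effect of the compound at the dose given. For the measured compounds named here, on these two numbers compound 2 stands highest; its only neighbour, compound 1, lies lower by a gap that is beyond the usual scatter of repeated measurements. Going by the values given here, since a lower number means a stronger effect, compound 2 is the one of the pair with the weaker effect at the dose given.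

Compound 3, `CCn1c(Cn2c(=O)oc3ccc(C)cc32)n[nH]c1=S`, has not been measured. It differs from compound 2 in one place: hydrogen in place of methyl on a saturated chain carbon, two bonds along the chain from an aromatic nitrogen. Cut one bond further out, the same change reads as propyl to ethyl. No step between two measured compounds follows this kind of change, so the size of its effect cannot be read from the numbers shown; a change of this small size is expected to give at most a modest step in this assay, quite possibly none beyond the scatter. The step from compound 2 to compound 3 is estimated at a number 10 percentage points lower from compound 2 to compound 3 (within the scatter). For compound 3 the expected value in this assay is 150%, with a range from 110% to 190%.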

Compound 3, a percentage reported as activity, at one dose (the size of the read-out at that dose, not a potency): 147%
Compound 3: middle estimate off by 3 percentage points, on the high side; the range from low to high includes it.
By their numbers in this assay, from the lowest: compound 1; then compound 3; then compound 2.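

For the compounds shown here, replacing methyl with hydrogen on a saturated chain carbon, two bonds along the chain from an aromatic nitrogen, turns the propyl chain of compound 2 into the ethyl chain of compound 3, and in this assay this gives a number 13 percentage points lower from compound 2 to compound 3 (beyond the scatter) as the only step that can be read so far. It shows that this chain is not a silent part of the molecule: removing one carbon from its end moves the read-out toward a stronger effect at the dose given, although the step is modest in size. No measurement shown here bears on what lies behind this step, so it stands as an observation without an explanation.

On these data alone, two chain lengths give one direction but not a trend, so it remains open whether a methyl group in this place would continue the movement or whether a butyl chain would reverse it. As far as these compounds go, how a branched isopropyl group, a cyclopropyl ring or a chain ending in an amine or a carboxylic acid would read in this assay also remains open.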